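This account rests on a few compounds, and the source may have more. Where it says the series, first, only, none or still open, it means among the compounds named here.

Working notes on the series. Three compounds have numbers in an assay on isolated protein for binding affinity to Equilibrative nucleoside transporter 1 (Homo sapiens); on this read-out lower numbers stand for stronger inhibition and higher numbers for weaker inhibition. Compound 1 `OC[C@H]1O[C@@H](n2cnc3c(OCc4ccccc4)ncnc32)[C@H](O)[C@@H]1O` gives 2090 nM. Compound 2 `CSc1ncnc2c1ncn2C1CCCCO1` gives 275000 nM. Compound 3 `CCCCn1cnc2c(SC(C)C)nc(N)nc21` gives 120000 nM. Compound 1 stands lowest of the three; compound 3 is nearest to it and compound 2 furthest, and both gaps are well beyond the scatter, so compound 1 is the most potent of the measured set. Among the compounds with values here, no pair of measured compounds differs in a single place, so no clean step is known from the data so far.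

Compound 4 `OC[C@H]1O[C@@H](n2cnc3c(CSc4ccccc4Cl)ncnc32)[C@H](O)[C@@H]1O` is the next compound for this assay. It departs from compound 1 as follows: ((2-chlorophenyl)sulfanyl)methyl in place of benzyloxy on an aromatic carbon. The size of the entering and leaving groups is close, each carries a single six-membered aromatic ring of carbon only, and neither adds a hydrogen-bond donor. Within the data shown here, with no measured step of comparable kind to lean on, the expectation is for a small step only, with a slight lean toward a lower number, and the change from compound 1 to compound 4 is estimated at a 1.4-fold lower number from compound 1 to compound 4 (0.14 log units; within the scatter), which is not expected to clear the scatter. Compound 4 is thus expected to give about 1500 nM in this assay, estimated within 300 nM to 8000 nM.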

Compound 4, half-maximal inhibitory concentration: 1780 nM
Compound 4: the middle estimate sits 1.2-fold (0.07 log units) below what was measured; measured number inside the range.
By their numbers in this assay, from the lowest: compounds 4 and 1 (each within the scatter of the next); then compound 3; then compound 2.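

In this assay, within the data shown here, the step from benzyloxy to ((2-chlorophenyl)sulfanyl)methyl on an aromatic carbon of the six-membered aromatic ring with 2 nitrogen gives a 1.2-fold lower number from compound 1 to compound 4 (0.07 log units; within the scatter) and is the first single-place comparison. The two compounds cannot be told apart on this read-out, so this place accepts both substituents, each with one six-membered aromatic ring of carbon only, without a change beyond the scatter, even though the link to that ring and the chlorine on it both differ. Nothing measured here offers an explanation for this result.

Among these compounds, the single step changes the link and adds the chlorine together, so it leaves open whether either change alone would give a separate shift, since their contributions cannot be separated from this pair. Also open, from the compounds shown here alone, is whether an aromatic ring is needed at this place at all, as a simple amine or a longer alkyl chain there would test, with the rest of the core of compound 1 held constant.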